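Arylpiperazine lactam amides: methoxy to isopropoxy on the aryl ring

A few compounds are considered here, and "the series" means these few. Any claim that something is new, unique, unknown or untested is made for them only; others in the source may bear on it.

Three compounds of the series have numbers in an assay on COS cells for binding affinity to Alpha-1D adrenergic receptor (Homo sapiens); on this read-out higher numbers stand for weaker inhibition and lower numbers for stronger inhibition. Compound 1 `COc1ccccc1N1CCN(CCCNC(=O)CN2CCCCC2=O)CC1` gives 10000 nM in this assay and stands at the top of the three numbers. Compound 3 `O=C(CN1CCCCC1=O)NCCN1CCN(c2ccc(F)cc2OCC(F)(F)F)CC1` gives 5350 nM in this assay, a difference from compound 1 that lies within the scatter. Compound 2 `CC(C)Oc1ccccc1N1CCN(CCNC(=O)CN2CCCCCC2=O)CC1` gives 505 nM in this assay, a difference from compound 1 that lies beyond the scatter; compound 2 carries a 2-isopropoxyphenyl group together with a shorter linker and a larger lactam ring, so no single change can be read from this pair.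

Compound 4 `CC(C)Oc1ccccc1N1CCN(CCCNC(=O)CN2CCCCC2=O)CC1` is not yet measured. It differs from compound 1 in one place: isopropyl in place of methyl on an oxygen on an aromatic ring. Within the data shown here, compound 2 is the only measured member with an isopropoxy group and has the lowest number of the three, which points the expectation toward a lower number for compound 4, though the other differences in compound 2 leave the size uncertain. A step from compound 1 to compound 4 of moderate size is expected, a 3.3-fold lower number from compound 1 to compound 4 (0.52 log units; beyond the scatter), in the direction of stronger inhibition. For compound 4 the estimate in this assay is 3000 nM, with a range from 800 nM to 10000 nM.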

Compound 4, inhibition constant: 80 nM
Compound 4: middle estimate off by 38-fold (1.57 log units), on the high side; the whole stated range lies above it.
By their numbers in this assay, from the lowest: compound 4; then compound 2; then compounds 3 and 1 (each within the scatter of the next).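

Working from the core of compound 1, exchanging methyl for isopropyl on an oxygen on an aromatic ring gives in this assay a step that reads a 130-fold lower number from compound 1 to compound 4 (2.10 log units; beyond the scatter), so this one position can by itself move the number by a large amount. The exchange leaves the linker and the lactam untouched and adds no ring, no hydrogen-bond donor or acceptor and no net charge, so in this pair the whole step goes with the change from methoxy to isopropoxy. Nothing available on this series bears on what lies behind the size of this step.

From the compounds shown here alone, whether the exchange gives a step of similar size on a shorter linker or with a larger lactam remains open, as does its effect alongside a fluorine on the aromatic ring. Also open, going by these compounds, is how the number responds to other groups on the same oxygen, such as ethyl, cyclopropyl or tert-butyl, and whether a free hydroxyl at this place would retain any of the step.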